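The source may report more compounds than this note shows. Statements on the series, on what has been measured and on what is new or still open speak of the compounds shown alone.

Working notes on the series. Three compounds share one core and differ only in the aryl group on the nitrogen of the pyrazole part of that core. Compound 1 `Cn1c(=O)[nH]c2c(cnn2-c2ccccc2[N+](=O)[O-])c1=N` gives 5% in an assay on membranes from brain for binding affinity to adenosine receptor A1 (Rattus norvegicus), read by radioligand binding, tested at 20 uM; a higher number here means more inhibition at the concentration tested (going by the name of the read-out), a lower number less inhibition. Compound 2 `Cn1c(=O)[nH]c2c(cnn2-c2cc(Cl)cc(Cl)c2)c1=N` gives 29% in this assay. Compound 3 `Cn1c(=O)[nH]c2c(cnn2-c2cccc([N+](=O)[O-])c2)c1=N` gives 2% in this assay. On these numbers compound 3 sits at the low end of the series: its gap to compound 1 lies within the scatter, so the two read as equal, while compound 2 lies clearly higher, beyond the scatter.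

Compound 4 `Cn1c(=O)[nH]c2c(cnn2-c2cccc(N)c2)c1=N` is not yet measured. It differs from compound 3 by amino in place of nitro on an aromatic carbon. For the measured compounds named here, no pair of measured compounds in the set differs in one place, so no measured step informs this change directly. With every value in the series low, the step is expected to be small, most likely none beyond the scatter, and in no reliable direction. Compound 4 is therefore expected at 8% in this assay, within 0% to 28%, which means an estimated step of a number 6 percentage points higher from compound 3 to compound 4 (within the scatter).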

Compound 4, a percentage reported as inhibition, at one concentration (the size of the read-out at that concentration, not a potency): 0%
Estimate against measurement, compound 4: 8 percentage points above; low and high end bracket the measured number.
By their numbers in this assay, from the lowest: compounds 4, 3 and 1 (each within the scatter of the next); then compound 2.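

Amino in place of nitro on an aromatic carbon, meta to a large group, gives the first single-place step of the series: in this assay the exchange yields a number 2 percentage points lower from compound 3 to compound 4 (within the scatter) and so no readable change. At this position, then, replacing nitro with the smaller amino does not lift the read-out at the concentration tested, even though the hydrogen-bond donor and acceptor counts differ between the two groups. Nothing measured explains this result or assigns a property to either group here.

Open, going by these compounds, is whether another group on this carbon, such as a chlorine, a carboxylic acid or a longer amine chain, would move the number beyond the scatter. Also open, on these data alone, is whether amino would give the same result on another carbon of that ring.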